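Fluoro to trifluoromethyl in a growth inhibitor

This account rests on a few compounds, and the source may have more. Where it says the series, first, only, none or still open, it means among the compounds named here.

Measured in a functional assay on A549 cells (Homo sapiens) for inhibition, read by sulforhodamine B assay; on this read-out higher numbers stand for weaker inhibition of growth and lower numbers for stronger inhibition of growth:
- Compound 1 `FC(F)(F)c1ccc(-c2ccc(-c3ccc(-c4nc5ccccc5[nH]4)cc3)cc2)cc1`: 36600 nM
- Compound 2 `Oc1cccc2[nH]c(-c3ccc(-c4ccc(-c5ccc(F)cc5)cc4)cc3)nc12`: 170 nM

Of these two compounds, compound 2 has the lower number at 170 nM, so it inhibits growth more strongly, and the gap to compound 1 lies well beyond the scatter of repeat measurements. These two compounds differ in more than one place, so their gap says little about any single group.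

Compound 3 `Oc1cccc2[nH]c(-c3ccc(-c4ccc(-c5ccc(C(F)(F)F)cc5)cc4)cc3)nc12` changes compound 2 in one place: trifluoromethyl in place of fluoro on an aromatic carbon. Trifluoromethyl stands in place of fluoro on an aromatic carbon, para to a large group. Among the compounds with values here, no measured pair shows this change alone, so the forecast is uncertain. In this assay, a slight weakening at most is expected, with no clear step beyond the scatter. The estimate is a 1.8-fold higher number from compound 2 to compound 3 (0.25 log units; within the scatter), a small expected rise. The expected value for compound 3 is 300 nM, with an estimated range from 90 nM to 1500 nM.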

Compound 3, concentration for 50% growth inhibition: 3610 nM
Beside the measured number, compound 3's estimate is 12-fold (1.08 log units) below it, outside the stated range (above it).
By their numbers in this assay, from the lowest: compound 2; then compound 3; then compound 1.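

In this assay, the group on this aromatic carbon clearly matters: trifluoromethyl in place of fluoro gives a 21-fold higher number from compound 2 to compound 3 (1.33 log units; beyond the scatter), so growth inhibition is much weaker with 4-(trifluoromethyl)phenyl than with 4-fluorophenyl. Compound 3 also allows the hydroxy group to be read on its own, as hydroxy in place of hydrogen gives a 10-fold lower number from compound 1 to compound 3 (1.01 log units; beyond the scatter), so with trifluoromethyl held constant, the hydroxy compound inhibits growth more strongly. No measurement here offers an explanation for either step.

Among the compounds shown, only fluoro and trifluoromethyl occupy this place, so it remains open how a chloro, methoxy or amino group would fare there. Within the data shown here, the hydroxy step is also seen only with trifluoromethyl present, so its size with fluoro remains unknown.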